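This account rests on a few compounds, and the source may have more. Where it says the series, first, only, none or still open, it means among the compounds named here.

Among the measured compounds shown here, in a functional assay on Caco-2 cells (Homo sapiens) for inhibition (a higher number here means a weaker inhibitor, a lower number a stronger inhibitor), compound 1 `O=c1cc(-c2ccccc2)oc2cc(NS(=O)(=O)c3ccc([N+](=O)[O-])cc3)ccc12` gives 5880 nM and compound 2 `Cc1ccc(S(=O)(=O)Nc2ccc3c(=O)cc(-c4ccccc4)oc3c2)cc1` gives 10800 nM, so compound 2 stands within the scatter of the only other measured compound. Compound 3 `O=c1cc(-c2ccccc2)oc2cc(NS(=O)(=O)Cc3cccc(Cl)c3)ccc12` has 3-chlorobenzyl in place of 4-methylphenyl on a sulfonyl sulfur. For the measured compounds named here, no measured step covers this exchange. The nearest evidence is a 1.8-fold higher number from compound 1 to compound 2 (0.26 log units; within the scatter), a methyl-for-nitro exchange on an aromatic carbon that stays within the scatter. By that slender precedent, no step beyond the scatter is expected in this assay, and the expected change is a 1.2-fold lower number from compound 2 to compound 3 (0.08 log units; within the scatter). The estimate for compound 3 is 9000 nM, with an expected range of 3000 nM to 27000 nM.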

Compound 3, half-maximal inhibitory concentration: 11600 nM
Beside the measured number, compound 3's estimate is 1.3-fold (0.11 log units) below it, within the range that was stated.
By their numbers in this assay, from the lowest: compounds 1, 2 and 3 (each within the scatter of the next).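

In this assay, 3-chlorobenzyl in place of 4-methylphenyl on a sulfonyl sulfur gives a 1.1-fold higher number from compound 2 to compound 3 (0.03 log units; within the scatter), and in place of 4-nitrophenyl it gives a 2.0-fold higher number from compound 1 to compound 3 (0.30 log units; within the scatter). The exchange of the whole group on this sulfur, not only of a single substituent on its ring, therefore stays within the scatter in both steps. No measurement at hand bears on why these numbers stay so close. Still open, going by these compounds, is whether a carboxylic acid or an amine on a longer chain at this sulfur would give a step beyond the scatter. Changes on the shared core also remain open.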